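The compounds below may be only part of what the source reports. "The series", "measured", "known", "first", "only" and "open" are said of these compounds alone.

Working notes on the series. All three measured compounds share one core and are read in a functional assay on HT-29 cells (Homo sapiens) for inhibition, read by MTT assay, with a stated time of 72 h; on this read-out lower numbers stand for stronger inhibition of growth and higher numbers for weaker inhibition of growth. Compound 1 `CC(C)(C)c1ccc(CNCCNS(=O)(=O)c2cc(C(F)(F)F)cc(C(F)(F)F)c2)cc1` gives 14000 nM. Compound 2 `O=S(=O)(NCCNCc1ccc(-c2ccccc2)cc1)c1cc(C(F)(F)F)cc(C(F)(F)F)c1` gives 2700 nM. Compound 3 `COc1cccc(CNCCCNS(=O)(=O)c2cc(C(F)(F)F)cc(C(F)(F)F)c2)c1` gives 10000 nM.

Compound 3 stands second highest of the three numbers. Its nearest neighbour is compound 1, whose number is within the scatter of that of compound 3, so no order between the two can be claimed. Compound 2 lies further off with a lower number beyond the scatter.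

Going by the values given here, the one step between measured compounds that differ in a single place is a 5.2-fold lower number from compound 1 to compound 2 (0.71 log units; beyond the scatter), a modest change at the benzylic aryl substituent.

Compound 4 `O=S(=O)(NCCCNCc1ccccc1Cl)c1cc(C(F)(F)F)cc(C(F)(F)F)c1` differs from compound 3 as follows:
2-chlorophenyl in place of 3-methoxyphenyl on a saturated chain carbon bound to an amine nitrogen

Among the compounds with values here, no measured step swaps one substituted benzyl for another in this way, so the step from compound 1 to compound 2 bears on it only loosely, as a sign that changes on that aryl ring can move this assay. A chlorine entering and a methoxy leaving is a smaller alteration than that one, and no direction is given by the data. The expected step is no change at the digits printed from compound 3 to compound 4 (within the scatter), that is, none beyond the scatter. Compound 4 is therefore estimated at 10000 nM, with a range from 3500 nM to 30000 nM.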

Compound 4, concentration for 50% growth inhibition: 20000 nM
Estimate against measurement, compound 4: 2.0-fold (0.30 log units) below, within the range that was stated.
By their numbers in this assay, from the lowest: compound 2; then compounds 3, 1 and 4 (each within the scatter of the next).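

In this assay, 2-chlorophenyl in place of 3-methoxyphenyl on a saturated chain carbon bound to an amine nitrogen gives a 2.0-fold higher number from compound 3 to compound 4 (0.30 log units; within the scatter), so no order can be claimed between these two compounds. Going by these compounds alone, this is the first reading of one substituted aryl group exchanged for another at this place, and unlike a 5.2-fold lower number from compound 1 to compound 2 (0.71 log units; beyond the scatter), which stays on one aryl ring and replaces tert-butyl with phenyl, it does not separate the pair beyond the scatter. The change swaps both the substituent and its printed ring number, and no available evidence bears on this result.

Still open, as far as these compounds go, is whether 2-methoxyphenyl or 3-chlorophenyl at this place would give a reading that separates the substituent from its ring number. Also open, from the compounds shown here alone, is whether an amine or a carboxylic acid on this aryl ring, or a longer chain in the shared core, would move the number beyond the scatter.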